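A dimethylamino swap in a tight growth-inhibition series

The source may hold more compounds than are shown below. What is called first, only, known or untested is meant among the compounds shown, and "the series" means these compounds.

In a functional assay on U-251 cells (Homo sapiens) for inhibition (a higher number here means a weaker inhibitor of growth, a lower number a stronger inhibitor of growth), compound 3 `NS(=O)(=O)c1ccc(/C=C/c2ccc(O)cc2)cc1` gives 15000 nM. That places it close to both of its measured relatives. Compound 1 `NS(=O)(=O)c1ccc(/C=C/c2ccc(O)c(O)c2)cc1` gives 16300 nM and compound 2 `NS(=O)(=O)c1ccc(/C=C/c2ccc(F)cc2)cc1` gives 7930 nM, and compound 3 lies within the usual scatter of each.

The next compound, compound 4 `CN(C)c1ccc(/C=C/c2ccc(S(N)(=O)=O)cc2)cc1`, has not yet been measured. It carries dimethylamino in place of hydroxy on an aromatic carbon, para to a large group: dimethylamino in place of hydroxy on an aromatic carbon.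

Among the measured compounds shown here, two measured steps bear on this change. The first is a 1.9-fold higher number from compound 2 to compound 3 (0.28 log units; within the scatter), with hydroxy in place of fluoro on an aromatic carbon. The second is a 1.1-fold lower number from compound 1 to compound 3 (0.04 log units; within the scatter), with hydrogen in place of hydroxy on an aromatic carbon. Neither exchange moved the number beyond the scatter, so no clear shift is expected in this assay this time. For the measured compounds named here, still, no measured compound here carries dimethylamino, so this expectation rests on indirect evidence and the range has to stay wide. The expected change is small, a 1.3-fold lower number from compound 3 to compound 4 (0.10 log units; within the scatter). For compound 4 the estimated value is 12000 nM, with an expected range of 4500 nM to 30000 nM.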

Compound 4, concentration for 50% growth inhibition: 11200 nM
Estimate against measurement, compound 4: 1.1-fold (0.03 log units) above, within the range that was stated.
By their numbers in this assay, from the lowest: compounds 2, 4, 3 and 1 (each within the scatter of the next, the first and the last beyond it).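

At this place on the ring, on an aromatic carbon para to a large group, dimethylamino brings 3 heavy atoms where hydroxy has 1 and 0 hydrogen-bond donors where hydroxy has 1, yet in this assay the result is a 1.3-fold lower number from compound 3 to compound 4 (0.13 log units; within the scatter) and, against the fluoro compound, a 1.4-fold higher number from compound 2 to compound 4 (0.15 log units; within the scatter). Among the compounds shown here, the earlier steps had covered only hydrogen, hydroxy and fluoro, so this is the first sign that a larger group without a hydrogen-bond donor can sit here and still leave the number within the scatter of its single-change neighbours, compound 2 and compound 3. Nothing shown gives a reason for this flat response.

Going by these compounds, what remains open is whether any group at this place can move the number beyond the scatter, since all the single-place steps seen so far stay within it. A carboxylic acid, a primary amine or a longer chain such as diethylamino would test that question, and each would show how far the tolerance seen with dimethylamino extends.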